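Swapping One Ring Group on a Short-Lived Compound

A few compounds are considered here, and "the series" means these few. Any claim that something is new, unique, unknown or untested is made for them only; others in the source may bear on it.

- compound 1 (`O=c1[nH]ccn1CCOc1nn(-c2ccccc2F)c2ccc(F)cc12`): 0.4 h
- compound 2 (`O=C1N(c2ccncc2)CCN1c1cccc2c1cnn2-c1ccccc1F`): 1.3 h
- compound 3 (`CC(C)(O)CC(=O)N1C[C@H]2CN(c3cccc4c3cnn4-c3ccccc3F)C(=O)[C@H]2C1`): 1.7 h

These three numbers come from an ADME assay on the whole organism (strain Sprague-Dawley) for metabolic stability, with Rattus norvegicus as the target, read by LC-MS (on this read-out lower numbers stand for a shorter-lived compound and higher numbers for a longer-lived compound), and give a first picture of how long each compound lasts in the animal. Compound 1 has the lowest number of the three, at 0.4 h in this set. Compound 2 (1.3 h) and compound 3 (1.7 h) both sit higher than compound 1, by more than the usual scatter of repeated measurements.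

The next compound to look at is compound 4 (`Fc1ccc2c(c1)c(OCCn1ccnc1)nn2-c1ccccc1F`), which has not been measured yet. It keeps the shared core of compound 1 and changes one group (a group of 5 heavy atoms (3 carbon, 2 nitrogen; one five-membered aromatic ring with 2 hetero atoms) in place of a group of 6 heavy atoms (3 carbon, 2 nitrogen, 1 oxygen; one five-membered aromatic ring with 2 hetero atoms), on a saturated chain carbon, two bonds along the chain from an oxygen on an aromatic ring). The 1H-imidazol-1-yl group that enters sits on a saturated chain carbon, two bonds along the chain from an oxygen on an aromatic ring.

For the measured compounds named here, no measured pair here differs in one place only, so no measured step shows what this change does. The group that leaves and the group that enters each hold one five-membered aromatic ring with 2 hetero atoms, and everything else in compound 1 (0.4 h) stays the same. The expected step of a 1.5-fold higher number from compound 1 to compound 4 (0.18 log units; within the scatter) is therefore small and upward, and it should stay within the scatter. For compound 4 the estimated half-life is 0.6 h (expected range 0.25 h to 1.5 h).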

Compound 4, half-life: 1.1 h
Beside the measured number, compound 4's estimate is 1.8-fold (0.26 log units) below it; the measured number falls inside the stated range.
By their numbers in this assay, from the lowest: compound 1; then compounds 4, 2 and 3 (each within the scatter of the next).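

In this assay, putting the 1H-imidazol-1-yl group on this saturated chain carbon gives a 2.8-fold higher number from compound 1 to compound 4 (0.44 log units; beyond the scatter). For the compounds shown here, this is the first step in the set that changes one place only, and it shows that the half-life responds at this position even when one five-membered aromatic ring with 2 hetero atoms replaces another. The entering group has 1 fewer heavy atom, 0 hydrogen-bond donors rather than 1, and no double bond outside aromatic rings, but this single step cannot separate these differences, and no measurement here explains the result.

The compounds shown leave open how the half-life would respond to a different kind of group at this place, such as an amine or a carboxylic acid. They also leave open whether a longer chain between the oxygen and the 1H-imidazol-1-yl group would change the result, and whether the same swap would give a similar step on a different core.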